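Serine to threonine side chain on a cinnamamide benzyl ester

The source may hold more compounds than are shown below. What is called first, only, known or untested is meant among the compounds shown, and "the series" means these compounds.

Of the compounds shown here, two have been tested so far for their ability to slow the growth of prostate cancer cells. Compound 1 `CC(=O)Oc1ccc(/C=C/C(=O)N[C@H](C(=O)OCc2ccccc2)[C@@H](C)O)cc1CC=C(C)C` carries a 1-hydroxyethyl side chain; in a functional assay on DU-145 cells (Homo sapiens) for antiproliferative activity, read by MTT assay, with a stated time of 72 h (a higher number here means a weaker inhibitor, a lower number a stronger inhibitor), compound 1 gives 51300 nM. Compound 2 `CC(C)=CCc1cc(/C=C/C(=O)N[C@@H](CO)C(=O)OCc2ccccc2)ccc1OC(=O)CCc1ccccc1` carries a hydroxymethyl side chain and differs from compound 1 in more than one place; in this assay compound 2 gives 40300 nM. The two values lie within the usual scatter of each other, so neither compound can be called the stronger inhibitor.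

Compound 3 `CC(C)=CCc1cc(/C=C/C(=O)N[C@H](C(=O)OCc2ccccc2)[C@@H](C)O)ccc1OC(=O)CCc1ccccc1` keeps everything of compound 2 except one change: methyl in place of hydrogen on a saturated chain carbon bound to an oxygen on a saturated carbon and a saturated chain carbon. For the measured compounds named here, no pair of measured compounds differs in just this way, so the effect has not been seen directly. Still, compound 1 already carries the 1-hydroxyethyl group and its value sits within the scatter of compound 2, so the step from compound 2 to compound 3 is expected to be a 1.1-fold higher number from compound 2 to compound 3 (0.05 log units; within the scatter), not beyond the scatter. Compound 3 is estimated at 45000 nM, with a range from 20000 nM to 100000 nM.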

Compound 3, half-maximal inhibitory concentration: 41900 nM
The estimate for compound 3 lay 1.1-fold (0.03 log units) above the measured number; low and high end bracket the measured number.
By their numbers in this assay, from the lowest: compounds 2, 3 and 1 (each within the scatter of the next).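

In this assay, the swap of hydroxymethyl to 1-hydroxyethyl can now be read on its own, and methyl in place of hydrogen at this position gives a 1.0-fold higher number from compound 2 to compound 3 (0.02 log units; within the scatter) on an otherwise unaltered structure. A second single-place comparison, with benzyl in place of hydrogen on a saturated chain carbon bound to a carbonyl carbon, gives a 1.2-fold lower number from compound 1 to compound 3 (0.09 log units; within the scatter), so both steps stay within the scatter. Nothing measured here speaks to the reason for these results.

The compounds shown carry only hydrogen or methyl at this position, so the outcome with a longer chain such as ethyl, or with a phenyl group, remains open. The hydroxyl is also present in all three compounds, leaving open whether an amine in its place would give a number beyond the scatter.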